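A few compounds are considered here, and "the series" means these few. Any claim that something is new, unique, unknown or untested is made for them only; others in the source may bear on it.

Compound 1, `Cc1ccc(Cl)cc1Nc1nc(C(F)(F)F)ccc1CNC(=O)C(C)c1ccc(NS(C)(=O)=O)c(F)c1`, gives 140 nM in a functional assay on CHO-K1 cells for antagonist activity at transient receptor potential cation channel subfamily V member 1 (Homo sapiens), read by FLIPR; a lower number here means a stronger inhibitor, a higher number a weaker inhibitor. Compound 2, `CC(C(=O)NCc1ccc(C(F)(F)F)nc1N(C)C)c1ccc(NS(C)(=O)=O)c(F)c1`, gives 2390 nM in this assay.

Among the measured compounds shown here, of these two, compound 2 stands at the highest number: its only neighbour is compound 1, and the step of a 17-fold higher number from compound 1 to compound 2 (1.23 log units; beyond the scatter) separates them. That step is the only one measured on this series, and it replaced the (5-chloro-2-methylphenyl)amino of compound 1 with the dimethylamino of compound 2, a large change in the group bound to the aromatic nitrogen.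

Compound 3, `CCCCN(C)c1nc(C(F)(F)F)ccc1CNC(=O)C(C)c1ccc(NS(C)(=O)=O)c(F)c1`, is not yet measured. It differs from compound 2 by propyl in place of hydrogen on a saturated chain carbon bound to a nitrogen on an aromatic ring, so that the dimethylamino of compound 2 becomes butyl(methyl)amino. For the measured compounds named here, the one measured step bears on it only indirectly: it shows that a larger group on this aromatic nitrogen went with a much lower number in this assay, but propyl is not an aryl ring, so only part of that drop is expected to carry over.

Compound 3 is therefore expected to show a moderately lower number than compound 2, a step of about a 2.7-fold lower number from compound 2 to compound 3 (0.42 log units; beyond the scatter) in this assay. The estimate for compound 3 in this assay is 900 nM, with a range from 300 nM to 2700 nM.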

Compound 3, half-maximal inhibitory concentration: 21.3 nM
Estimate against measurement, compound 3: 42-fold (1.63 log units) above; measured number outside the range, below it.
By their numbers in this assay, from the lowest: compound 3; then compound 1; then compound 2.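

In this assay, changing one methyl of the dimethylamino to butyl gives a 110-fold lower number from compound 2 to compound 3 (2.05 log units; beyond the scatter), so a saturated chain alone, with no aryl ring, is enough for a large drop at this position. The same butyl(methyl)amino also goes beyond the (5-chloro-2-methylphenyl)amino, with a 6.6-fold lower number from compound 1 to compound 3 (0.82 log units; beyond the scatter), a modest step that makes compound 3 the strongest inhibitor of the three. The single earlier step could be read as a gain tied to the aryl ring, but these numbers show that the ring is not required and that, among these three groups, the aryl-bearing one does not give the lowest number.

No measurement shown here accounts for the size of the drop brought by the butyl chain. Open too, going by these compounds, is how sharply the number depends on the chain: whether an ethyl or a hexyl in place of the butyl, a branched chain such as isobutyl, or a cyclic amine such as piperidine in place of the whole butyl(methyl)amino would hold, lower or lose the number of compound 3.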